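The source may report more compounds than this note shows. Statements on the series, on what has been measured and on what is new or still open speak of the compounds shown alone.

Measured so far:
compound 1 `CNc1nc(Nc2ccc(C)c([N+](=O)[O-])c2)ncc1C(=O)Nc1cc(NC(=O)c2ccccc2OC)ccc1C` — in a functional assay on K562 cells (Homo sapiens) for antiproliferative activity, read by CellTiter-Glo and CCK-8 assay, with a stated time of 72 h (on this read-out higher numbers stand for weaker inhibition of growth and lower numbers for stronger inhibition of growth), gives > 10000 nM
compound 2 `CNc1nc(Nc2ccc(C)c([N+](=O)[O-])c2)ncc1C(=O)Nc1cc(NC(=O)c2cccc(OC)c2)ccc1C` — in this assay gives 480 nM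
compound 3 `CNc1nc(Nc2ccc(C)c([N+](=O)[O-])c2)ncc1C(=O)Nc1cc(NC(=O)c2ccc(OC)c(OC)c2)ccc1C` — in this assay gives 680 nM

The value of compound 1 is a limit of the assay, not a number (the limit of > 10000 nM in this assay, at which 1 of the 3 values shown sits). Of the two numbers, compound 3 is not separated from compound 2: a 1.4-fold higher number from compound 2 to compound 3 (0.15 log units; within the scatter). Compound 4 `CNc1nc(Nc2ccc(C)c([N+](=O)[O-])c2)ncc1C(=O)Nc1cc(NC(=O)c2cc(OC)cc(OC)c2)ccc1C` differs from compound 3 by 3,5-dimethoxyphenyl in place of 3,4-dimethoxyphenyl on a carbonyl carbon. Among the measured compounds shown here, the steps that bear on this were large only when 2-methoxyphenyl was replaced, an at least 20-fold lower number from compound 1 to compound 2 (1.31 log units; beyond the scatter) and an at least 14-fold lower number from compound 1 to compound 3 (1.16 log units; beyond the scatter), while adding a methoxy to 3-methoxyphenyl, a 1.4-fold higher number from compound 2 to compound 3 (0.15 log units; within the scatter), stayed within the scatter. Both 3,4-dimethoxyphenyl and 3,5-dimethoxyphenyl contain the 3-methoxyphenyl of compound 2, so for compound 4 no step beyond the scatter is expected, a 1.1-fold lower number from compound 3 to compound 4 (0.05 log units; within the scatter). Compound 4 is estimated at 600 nM, between 250 nM and 1500 nM.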

Compound 4, concentration for 50% growth inhibition: 1070 nM
The estimate for compound 4 lay 1.8-fold (0.25 log units) below the measured number; the range from low to high includes it.
By their numbers in this assay, from the lowest: compounds 2, 3 and 4 (each within the scatter of the next, the first and the last beyond it). At a limit, above all of these: compound 1.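

Moving a methoxy from 3,4-dimethoxyphenyl to 3,5-dimethoxyphenyl does not separate the pair: a 1.6-fold higher number from compound 3 to compound 4 (0.20 log units; within the scatter). Against 3-methoxyphenyl, the second methoxy of 3,5-dimethoxyphenyl gives a 2.2-fold higher number from compound 2 to compound 4 (0.35 log units; beyond the scatter), whereas that of 3,4-dimethoxyphenyl stayed within the scatter, so the cost of a second methoxy depends slightly on where it sits. Replacing 2-methoxyphenyl with 3,5-dimethoxyphenyl still gives an at least 9.3-fold lower number from compound 1 to compound 4 (0.97 log units; beyond the scatter), and this step rests on a limit: the limit of > 10000 nM in this assay, at which 1 of the 4 values shown sits.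

The compounds shown leave open whether this phenyl accepts anything other than methoxy, such as an amine, a fluorine or a carboxylic acid.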